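A few compounds are considered here, and "the series" means these few. Any claim that something is new, unique, unknown or untested is made for them only; others in the source may bear on it.

Measured so far:
- compound 1 `COc1cc(-c2nn(-c3cccc(NC(=O)Nc4cc(C(F)(F)F)cc(C(F)(F)F)c4)c3)cc2-c2ccncc2)ccc1Cl`: 937 nM
- compound 2 `COc1cc(-c2nn(-c3cccc(NC(=O)Nc4ccc(Cl)c(Cl)c4)c3)cc2-c2ccncc2)ccc1Cl`: 2130 nM

Two compounds share one core and differ only in the aryl group carried on the urea. In a functional assay on OVCAR-5 cells (Homo sapiens) for inhibition, read by sulforhodamine B assay, with a stated time of 48 h (on this read-out lower numbers stand for stronger inhibition of growth and higher numbers for weaker inhibition of growth), compound 1 gives 937 nM, while compound 2 gives 2130 nM, which is the higher of the two numbers, and the gap between them lies beyond the usual scatter. Compound 3 `COc1cc(-c2nn(-c3cccc(NC(=O)Nc4cccc(C(F)(F)F)c4)c3)cc2-c2ccncc2)ccc1Cl` has not yet been measured. It differs from compound 2 by a single exchange: 3-(trifluoromethyl)phenyl in place of 3,4-dichlorophenyl on an amide-type nitrogen. This moves compound 3 part of the way toward compound 1, which carries two trifluoromethyl groups on that ring. No directly comparable step is on record, so the expectation rests only on the two numbers shown. A modest move toward a lower number than compound 2, possibly still within the scatter, seems reasonable, so compound 3 is expected to give 1500 nM in this assay, in a range from 600 nM to 4000 nM, meaning an estimated step of a 1.4-fold lower number from compound 2 to compound 3 (0.15 log units; within the scatter).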

Compound 3, concentration for 50% growth inhibition: 1270 nM
Compound 3: the middle estimate sits 1.2-fold (0.07 log units) above what was measured; measured number inside the range.
By their numbers in this assay, from the lowest: compounds 1, 3 and 2 (each within the scatter of the next, the first and the last beyond it).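

In this assay, 3-(trifluoromethyl)phenyl in place of 3,4-dichlorophenyl on the amide-type nitrogen gives a 1.7-fold lower number from compound 2 to compound 3 (0.22 log units; within the scatter) and so cannot be told apart from the noise of repeated measurements. Hydrogen in place of one trifluoromethyl group on an aromatic carbon gives a 1.4-fold higher number from compound 1 to compound 3 (0.13 log units; within the scatter) and is equally unresolved, so compound 3 lies within the scatter of both neighbours, and the clear gap between compound 1 and compound 2 cannot be pinned on either single step. No supporting data explain these numbers.

From the compounds shown here alone, all three aryl groups on the urea carry only chlorine or trifluoromethyl, so it remains open how this position would respond to an unsubstituted phenyl or to a ring bearing an amine or a carboxylic acid. Going by these compounds, whether these small steps hold in other cell lines also remains open.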